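The source may hold more compounds than are shown below. What is called first, only, known or untested is meant among the compounds shown, and "the series" means these compounds.

In a physicochemical assay for solubility (on this read-out lower numbers stand for lower solubility and higher numbers for higher solubility), compound 1 `CN(C)c1ccc(C(=O)N2CCC(NS(=O)(=O)c3cc(S(=O)(=O)c4ccccc4)ccc3C(F)(F)F)CC2)cc1` gives 50000 nM and compound 2 `O=C(c1cccnc1)N1CCC(NS(=O)(=O)c2cc(S(=O)(=O)c3ccccc3)ccc2C(F)(F)F)CC1` gives 50000 nM, which amounts to no change at the digits printed from compound 1 to compound 2 (within the scatter). Compound 3 `O=C(O)c1cccc(S(=O)(=O)N2CCC(NS(=O)(=O)c3cc(S(=O)(=O)c4ccccc4)ccc3C(F)(F)F)CC2)c1` gives 12500 nM, the lowest of the three numbers. Compound 4 `N#Cc1cccc(S(=O)(=O)N2CCC(NS(=O)(=O)c3cc(S(=O)(=O)c4ccccc4)ccc3C(F)(F)F)CC2)c1` keeps everything in compound 3 except one group, with cyano in place of carboxy on an aromatic carbon, meta to a large group: cyano in place of carboxy on an aromatic carbon. The (3-carboxyphenyl)sulfonyl group thus becomes (3-cyanophenyl)sulfonyl.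

Among the compounds with values here, two measured steps bear on this part of the molecule, a 4.0-fold lower number from compound 1 to compound 3 (0.60 log units; beyond the scatter) and a 4.0-fold lower number from compound 2 to compound 3 (0.60 log units; beyond the scatter). Both are modest, but each exchanges the whole group on the amine nitrogen in the ring, so neither isolates the carboxy group. Within the data shown here, no measured pair changes that group alone, and the data therefore fix no direction for this step. Among the measured compounds shown here, with those two steps as the only guide to size, a shift no larger than theirs is expected in this assay. The lean towards a lower number is a judgement rather than a measured trend. The expected change is a 2.0-fold lower number from compound 3 to compound 4 (0.30 log units; within the scatter). For compound 4 the estimated value is 6250 nM, with an expected range of 2000 nM to 25000 nM.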

Compound 4, solubility: 6300 nM
Estimate against measurement, compound 4: 1.0-fold (0.00 log units) below; the measured number falls inside the stated range.
By their numbers in this assay, from the lowest: compounds 4 and 3 (each within the scatter of the next); then compounds 1 and 2 (each within the scatter of the next).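

In this assay the exchange of carboxy for cyano, on an aromatic carbon, meta to a large group, can now be read on its own, and it gives a 2.0-fold lower number from compound 3 to compound 4 (0.30 log units; within the scatter), so this change does not separate the two (3-substituted phenyl)sulfonyl compounds, although 1 hydrogen-bond donor leaves with the carboxy group. The wider gaps belong to exchanges of the whole group on the amine nitrogen in the ring, with (3-cyanophenyl)sulfonyl giving a 7.9-fold lower number from compound 2 to compound 4 (0.90 log units; beyond the scatter) and a 7.9-fold lower number from compound 1 to compound 4 (0.90 log units; beyond the scatter), and both steps lie beyond the scatter, like those seen earlier for the carboxy compound. Nothing given here offers a measured reason for any of these numbers.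

On these data alone, what remains open is which part of those larger exchanges carries the gap, since the sulfonyl link and the ring it bears change together, and a (pyridin-3-yl)sulfonyl group on the same nitrogen would begin to pull them apart. The compounds shown also leave open how a primary amide, a methyl ester or an amine would read on the same aromatic carbon.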